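The source may report more compounds than this note shows. Statements on the series, on what has been measured and on what is new or still open speak of the compounds shown alone.

Compound 2 `OCCC(NC1CCN(CCCc2c[nH]c3ccc(-n4cnnc4)cc23)CC1)c1ccccc1` gives 150 nM in an assay on CHO cells for binding affinity to 5-hydroxytryptamine receptor 1B (Homo sapiens); on this read-out lower numbers stand for stronger inhibition and higher numbers for weaker inhibition; compound 1 `COC[C@H](NC1CCN(CCCc2c[nH]c3ccc(-n4cnnc4)cc23)CC1)c1ccccc1` gives 210 nM, and the two values lie within the scatter of each other. Compound 3 `NC(=O)OC[C@H](NC1CCN(CCCc2c[nH]c3ccc(-n4cnnc4)cc23)CC1)c1ccccc1` is not yet measured; it differs from compound 2 by 2-(carbamoyloxy)-1-phenylethyl in place of 3-hydroxy-1-phenylpropyl on an amine nitrogen. Going by the values given here, the only comparable step, a 1.4-fold lower number from compound 1 to compound 2 (0.15 log units; within the scatter), also exchanged the group on this amine nitrogen and stayed within the scatter, so no step beyond the scatter is expected for compound 3 in this assay, in either direction. The expected value for compound 3 is 180 nM (range 70 nM to 450 nM), which amounts to an expected 1.2-fold higher number from compound 2 to compound 3 (0.08 log units; within the scatter).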

Compound 3, half-maximal inhibitory concentration: 120 nM
Estimate against measurement, compound 3: 1.5-fold (0.18 log units) above; measured number inside the range.
By their numbers in this assay, from the lowest: compounds 3, 2 and 1 (each within the scatter of the next).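

In this assay, 2-(carbamoyloxy)-1-phenylethyl on the amine nitrogen cannot be told apart from 3-hydroxy-1-phenylpropyl, with a 1.3-fold lower number from compound 2 to compound 3 (0.10 log units; within the scatter). Carbamoyl in place of methyl on the oxygen gives a 1.8-fold lower number from compound 1 to compound 3 (0.24 log units; within the scatter), so this position has now accepted a larger group with both exchanges staying within the scatter. Nothing available explains this result. As far as these compounds go, it remains open whether a primary amine or a carboxylic acid in place of the carbamoyl, or a longer chain on the amine nitrogen, would give a step beyond the scatter.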